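The source may hold more compounds than are shown below. What is called first, only, known or untested is meant among the compounds shown, and "the series" means these compounds.

Measured so far:
- compound 1 `CC[C@@H](Nc1c(C#N)c(-c2ccc(-c3ccc(F)cc3)cc2)nc2cnccc12)C(N)=O`: in a physicochemical assay for lipophilicity, read by HPLC, at pH 7.5 (a higher number here means a more lipophilic compound, a lower number a more polar compound), compound 1 gives 2.7
- compound 2 `CCOc1ccccc1-c1ccc(-c2nc3cnccc3c(C[C@H](C)C(N)=O)c2C#N)cc1`: in this assay compound 2 gives 3

Compound 1 has the lower of the two numbers, but compound 2 sits within the scatter of it, so the two values show no real difference in this assay. Compound 2 also differs from compound 1 in more than one place, so no single step can be read from the pair.

Compound 3 `CC[C@@H](Nc1c(C#N)c(-c2ccc(-c3ccccc3C)cc2)nc2cnccc12)C(N)=O` has not yet been measured. It follows from compound 1 by one change on the shared core: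

2-methylphenyl in place of 4-fluorophenyl on an aromatic carbon

No measured step covers a swap of this kind in the series. A small rise in this assay is expected, at the edge of the scatter rather than clearly beyond it. For compound 3 the estimate in this assay is 3, between 2.6 and 3.4, a step of a number 0.30 log units higher from compound 1 to compound 3 (within the scatter).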

Compound 3, distribution coefficient: 3
Compound 3: middle estimate and measured number agree at the digits printed; the measured number falls inside the stated range.
By their numbers in this assay, from the lowest: compounds 1, 2 and 3 (each within the scatter of the next).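

In this assay, among the compounds shown here, 2-methylphenyl in place of 4-fluorophenyl on an aromatic carbon, para to a large group, gives a number 0.30 log units higher from compound 1 to compound 3 (within the scatter) as the first single-place step. This position therefore accepts the exchange of 4-fluorophenyl for 2-methylphenyl, each with 7 heavy atoms and one six-membered aromatic ring of carbon only, without a step beyond the scatter. No independent measurement bears on this result.

For the compounds shown here, the single step covers only these two uncharged groups, so it remains open how this position would respond to a phenyl ring carrying an amine or a carboxylic acid. Compound 2 differs from compound 1 and compound 3 in more than one place, so the effect of its ethoxy group cannot be separated from its other differences.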